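Ethylamino to Dimethylamino: What Compound 4 May Show

This account rests on a few compounds, and the source may have more. Where it says the series, first, only, none or still open, it means among the compounds named here.

Compound 1, `CCNCC(=O)Nc1cc(OC)ccc1C(=O)c1ccc(OC)c2c1C=CC(C)(C)O2`, gives 7230 nM in a functional assay on MCF7 cells (Homo sapiens) for antiproliferative activity, read by MTT assay, with a stated time of 48 h; a lower number here means a stronger inhibitor, a higher number a weaker inhibitor.
Compound 2, `COc1ccc(C(=O)c2ccc(OC)c3c2C=CC(C)(C)O3)c(NC(=O)CN(C)C)c1`, gives 6530 nM in this assay.
Compound 3, `C=C(c1ccc2c(c1)C=CC(C)(C)O2)c1ccc(OC)cc1NC(=O)CNCC`, gives 3370 nM in this assay.

Compound 1 and compound 2 share a core and differ only by dimethylamino in place of ethylamino on a saturated chain carbon bound to a carbonyl carbon. That change made a 1.1-fold lower number from compound 1 to compound 2 (0.04 log units; within the scatter), so the two values sit within the usual scatter of each other and no order between them can be read from the numbers.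

Compound 3 carries a different core; the difference between the two cores is not broken down here. Its value lies within the scatter of compound 2 and beyond the scatter of compound 1.

Compound 4, `C=C(c1ccc2c(c1)C=CC(C)(C)O2)c1ccc(OC)cc1NC(=O)CN(C)C`, has not yet been measured. It differs from compound 3 by dimethylamino in place of ethylamino on a saturated chain carbon bound to a carbonyl carbon, the same change that separates compound 2 from compound 1, at the same place. Because the earlier step was a 1.1-fold lower number from compound 1 to compound 2 (0.04 log units; within the scatter), the step from compound 3 to compound 4 is expected to be small as well, about a 1.1-fold lower number from compound 3 to compound 4 (0.04 log units; within the scatter). Compound 4 is therefore estimated to give roughly 3100 nM in this assay, most likely between 1600 nM and 6200 nM.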

Compound 4, half-maximal inhibitory concentration: 940 nM
The estimate for compound 4 lay 3.3-fold (0.52 log units) above the measured number; measured number outside the range, below it.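

In this assay, dimethylamino in place of ethylamino on the core of compound 3 gave a 3.6-fold lower number from compound 3 to compound 4 (0.55 log units; beyond the scatter), a clear gain on this core, whereas the same swap on the core of compound 1 made no readable difference. The size of this change therefore did not carry over from one core to the other: the same change on two cores in this assay, a 1.1-fold lower number (0.04 log units; within the scatter) from compound 1 to compound 2 and a 3.6-fold lower number (0.55 log units; beyond the scatter) from compound 3 to compound 4, 3.2-fold (0.51 log units) apart, beyond the scatter of two such steps. This shows that a step measured on one core is not a safe guide to the step on another in this series, but it does not show which feature of the two cores sets them apart, and two cores are too few to predict what a third would do.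

Still open, on these data alone, is whether other groups in the same place, such as diethylamino or an unsubstituted amino group, would also separate the two cores. As far as these compounds go, it is equally open whether a longer chain carrying the dimethylamino group would keep the gain seen with compound 4.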